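This account rests on a few compounds, and the source may have more. Where it says the series, first, only, none or still open, it means among the compounds named here.

Compound 1 `COc1cc(C)nc2n/c(=N/C(=O)c3c(-c4ccc(Cl)cc4Cl)noc3C)sn12`: 80.6%
Compound 2 `CSc1cc(C)nc2n/c(=N/C(=O)c3c(-c4ccc(Cl)cc4Cl)noc3C)sn12`: 70.6%

In a functional assay on the whole organism for inhibition, with Digitaria ciliaris as the target, with a stated time of 72 h, tested at 100 mg/L (a lower number here means less inhibition of growth, a higher number more inhibition of growth at the concentration tested), compound 1 stands highest of the two numbers. Its nearest neighbour is compound 2. Within the data shown here, the only measured step is a number 10 percentage points lower from compound 1 to compound 2 (within the scatter), which concerns the methoxy group and stays within the scatter. Compound 3 `COc1cc(Cl)nc2n/c(=N/C(=O)c3c(-c4ccc(Cl)cc4Cl)noc3C)sn12` differs from compound 1 by chloro in place of methyl on an aromatic carbon. Among the measured compounds shown here, no measured step touches this position, so the data give no direction for it; only a small step, if any, is expected, namely a number 5.6 percentage points lower from compound 1 to compound 3 (within the scatter). Compound 3 is therefore estimated at 75% in this assay, with a range from 50% to 92%.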

Compound 3, percent growth inhibition at one concentration: 72.8%
Compound 3: middle estimate off by 2.2 percentage points, on the high side; measured number inside the range.
By their numbers in this assay, from the lowest: compounds 2, 3 and 1 (each within the scatter of the next).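

In this assay, chloro in place of methyl on the aromatic carbon next to the ring nitrogen gives a number 7.8 percentage points lower from compound 1 to compound 3 (within the scatter), the only reading at this position among the compounds shown. With the methoxy group kept, methyl and chloro are therefore not told apart at the concentration tested, so this carbon need not carry methyl for the growth inhibition seen here. Nothing measured here accounts for this result. From the compounds shown here alone, whether an amine or a longer chain at this carbon would also stay within the scatter remains open. So does whether chloro would read the same alongside methylsulfanyl in place of methoxy.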